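The compounds below may be only part of what the source reports. "The series", "measured", "known", "first", "only" and "open" are said of these compounds alone.

In a functional assay on T47D cells (Homo sapiens) for cytotoxicity, read by colorimetric assay and MTT assay (a lower number here means a stronger inhibitor, a higher number a weaker inhibitor), compound 1 (`COc1ccc(-c2cc3cccc(OC)c3nc2O)cc1`) gives 10000 nM and compound 2 (`CCOC(=O)Cn1c(=O)c(-c2ccc(OC)cc2)cc2c(OC)cc(OC)cc21`) gives 10000 nM, so compound 2 stands level with compound 1. Compound 3 (`COc1ccc(-c2cc3c(OC)cc(OC)cc3n(CCCC#N)c2=O)cc1`) keeps the core of compound 2 and changes one side chain, on a saturated chain carbon bound to an aromatic nitrogen: 2-cyanoethyl in place of ethoxycarbonyl on a saturated chain carbon bound to an aromatic nitrogen. Here 2-cyanoethyl comes in place of ethoxycarbonyl. Within the data shown here, no measured pair shows what such a swap does, so in this assay the estimated 1.3-fold lower number from compound 2 to compound 3 (0.10 log units; within the scatter) is expected to stay within the scatter, with no clear direction. Compound 3 is expected at about 8000 nM, with an estimated range from 2500 nM to 25000 nM.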

Compound 3, half-maximal inhibitory concentration: 10000 nM
Compound 3: middle estimate off by 1.3-fold (0.10 log units), on the low side, within the range that was stated.
By their numbers in this assay, from the lowest: compounds 1, 2 and 3 (each within the scatter of the next).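

In this assay, replacing ethoxycarbonyl with 2-cyanoethyl on a saturated chain carbon bound to an aromatic nitrogen gives no change at the digits printed from compound 2 to compound 3 (within the scatter) for this pair. Among these compounds, this is the first one-place comparison at this position, and it shows that this particular swap leaves the number unmoved. Nothing measured here explains that result.

From the compounds shown here alone, it remains open whether a carboxylic acid or an amine at this position would shift the number in this assay at all. Whether a change elsewhere on the shared core would do so is also unresolved.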